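Adding a second fluoro group to compound 2

A few compounds are considered here, and "the series" means these few. Any claim that something is new, unique, unknown or untested is made for them only; others in the source may bear on it.

Three compounds sharing one core have been run in an ADME assay on the whole organism with Oryza sativa as the target, tested at 10 uM; on this read-out higher numbers stand for a weaker effect at the one concentration tested and lower numbers for a stronger effect. Compound 1 `C[C@H](NC(=O)Nc1cccc(C(F)(F)F)c1)c1ccccc1` carries a trifluoromethyl group and gives 92%. Compound 2 `C[C@H](NC(=O)Nc1cccc(F)c1)c1ccccc1` carries a single fluoro group in its place and gives 88%. Compound 3 `C[C@H](NC(=O)Nc1ccc(F)c(F)c1)c1ccccc1` carries two fluoro groups and gives 98%. On these three numbers compound 2 stands lowest, but the step of a number 4 percentage points lower from compound 1 to compound 2 (within the scatter) and the step of a number 10 percentage points higher from compound 2 to compound 3 (within the scatter) are each within the scatter, so the three values cannot be told apart with confidence.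

Compound 4 `C[C@H](NC(=O)Nc1cc(F)cc(F)c1)c1ccccc1` has not yet been measured. It differs from compound 2 in one place: fluoro in place of hydrogen on an aromatic carbon. For the measured compounds named here, the one measured step of this same kind, fluoro in place of hydrogen on an aromatic carbon, is a number 10 percentage points higher from compound 2 to compound 3 (within the scatter), which sits inside the scatter. The other step, a number 4 percentage points lower from compound 1 to compound 2 (within the scatter), is likewise inside the scatter. Nothing in these numbers points to a shift beyond the scatter in this assay.

Compound 4 is therefore expected to give about 93%, with a likely range from 82% to 103%. The expected step of a number 5 percentage points higher from compound 2 to compound 4 (within the scatter) would itself be within the scatter.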

Compound 4, a percentage reported as activity, at one concentration (the size of the read-out at that concentration, not a potency): 99%
For compound 4 the middle estimate is 6 percentage points below the measured one; low and high end bracket the measured number.
By their numbers in this assay, from the lowest: compounds 2, 1, 3 and 4 (each within the scatter of the next, the first and the last beyond it).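

In this assay, fluoro in place of hydrogen at this place, an aromatic carbon meta to a fluoro group and meta to a large group, goes with a number 11 percentage points higher from compound 2 to compound 4 (beyond the scatter), the first step among these compounds to lie beyond the usual scatter. Higher numbers stand for a weaker effect at the one concentration tested, so this change moves the read-out towards a weaker effect, in the same direction as a number 10 percentage points higher from compound 2 to compound 3 (within the scatter), although that earlier step stays within the scatter. The shift is only modest, and no measurement shown here explains it.

From the compounds shown here alone, it remains open whether this shift belongs to fluoro specifically or would also appear with a different group at the same place, such as a chlorine atom, a methyl group, a methoxy group or an amine. Also open, going by these compounds, is whether the same change would give a similar step on a compound that differs elsewhere in the shared core, since every step here rests on a single pair of compounds tested at one concentration.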